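A few compounds are considered here, and "the series" means these few. Any claim that something is new, unique, unknown or untested is made for them only; others in the source may bear on it.

Going by the values given here, in a functional assay on CCRF-CEM cells (Homo sapiens) for inhibition (on this read-out lower numbers stand for stronger inhibition and higher numbers for weaker inhibition), compound 2 `CS(=O)(=O)OC[C@H]1OC(n2cc(F)c(=O)[nH]c2=O)[C@H](O)[C@@H]1O` gives 660 nM, the lower of the two numbers so far, while compound 1 `O=c1[nH]c(=O)n(C2O[C@H](CCl)[C@@H](O)[C@H]2O)cc1F` gives 22000 nM. Next in the series is compound 3 `O=c1[nH]c(=O)n(C2O[C@H](CBr)[C@@H](O)[C@H]2O)cc1F`, with the change bromo in place of (methylsulfonyl)oxy on a saturated chain carbon bound to a saturated ring carbon. Among the compounds with values here, the only measured step bearing on this is the large 33-fold lower number from compound 1 to compound 2 (1.52 log units; beyond the scatter), where (methylsulfonyl)oxy takes the place of chloro at the same carbon. Compound 3 carries a halogen there, as does compound 1, so a move back toward the 22000 nM of compound 1 is expected, though perhaps not all the way. Bromo itself is untested, and a single step fixes no firm size. In this assay, a sizeable step to a higher number is expected, estimated as a 9.1-fold higher number from compound 2 to compound 3 (0.96 log units; beyond the scatter). The estimate for compound 3 is 6000 nM, with an expected range of 1200 nM to 30000 nM.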

Compound 3, half-maximal inhibitory concentration: 3100 nM
For compound 3 the middle estimate is 1.9-fold (0.29 log units) above the measured one, and the stated range covers the measured number.
By their numbers in this assay, from the lowest: compound 2; then compound 3; then compound 1.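

At the saturated chain carbon bound to a saturated ring carbon, the identity of the halogen matters in this assay: bromo in place of chloro gives a 7.1-fold lower number from compound 1 to compound 3 (0.85 log units; beyond the scatter) and so recovers part of the gap to the (methylsulfonyl)oxy compound. Bromo in place of (methylsulfonyl)oxy still gives a 4.7-fold higher number from compound 2 to compound 3 (0.67 log units; beyond the scatter) and so does not match that group. Across these three compounds, the numbers rise from (methylsulfonyl)oxy through bromo to chloro, with every step beyond the scatter, and no supporting data explain this order.

Still open, from the compounds shown here alone, is where iodo, a free hydroxy or an amine at this carbon would fall relative to these three groups. Also open, going by these compounds, is whether a larger sulfonate ester, such as (phenylsulfonyl)oxy, would give a lower number than (methylsulfonyl)oxy.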